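This account rests on a few compounds, and the source may have more. Where it says the series, first, only, none or still open, it means among the compounds named here.

Among the measured compounds shown here, compound 2 `c1ccc(-c2nccs2)c(OCC2=NCCN2)c1` is the only compound with a number in a functional assay for activation of Alpha-1B adrenergic receptor (Homo sapiens), read by calcium flux (a lower number here means that less compound is needed, a higher number that more compound is needed for the effect), where compound 2 gives 20 nM. Compound 1 `c1cnc(-c2ccccc2OCC2=NCCN2)nc1` reaches only a limit of the assay in this assay, namely < 100000 nM. For the measured compounds named here, the single measured step, a step that the limit leaves unreadable from compound 1 to compound 2, cannot be read, as the limit of < 100000 nM in this assay, at which 1 of the 2 values shown sits, shows. Compound 3 `Cn1nccc1-c1ccccc1OCC1=NCCN1` differs from compound 2 in 1-methyl-1H-pyrazol-5-yl in place of 1,3-thiazol-2-yl on an aromatic carbon. No readable step bears on this exchange of one five-membered aromatic ring for another, so the direction is open. A moderate loss is nevertheless expected, a 6.0-fold higher number from compound 2 to compound 3 (0.78 log units; beyond the scatter). Compound 3 is thus estimated at 120 nM, within 25 nM to 800 nM.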

Compound 3, half-maximal effective concentration: < 100000 nM
Compound 3: only a limit was reported (the forecaster's own chance of this, stated with the estimate: 5%); the middle value is on the limit's open side.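

No new step can be read between compound 1, compound 2 and compound 3 in this assay, since the value of compound 3 is also a limit: the limit of < 100000 nM in this assay, at which 2 of the 3 values shown sit.

The compounds shown leave open how large the gap from compound 2 to compound 3 is, and whether compound 1 and compound 3 differ at all.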